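A few compounds are considered here, and "the series" means these few. Any claim that something is new, unique, unknown or untested is made for them only; others in the source may bear on it.

Measured so far:
compound 1, `CC(/C=N/Nc1ccc([N+](=O)[O-])cc1)=N\NC(=O)c1ccccc1Cl`: in a functional assay on cells (Splenocyte, Mus musculus, strain BALB/c) for inhibition, read by scintillation counting and thymidine incorporation, with a stated time of 72 h (a higher number here means a weaker inhibitor, a lower number a stronger inhibitor), compound 1 reaches only the limit > 12000 nM.
compound 2, `CC(/C=N/Nc1ccc([N+](=O)[O-])cc1)=N\NC(=O)c1ccccc1C`: in this assay compound 2 gives 6000 nM.

For the measured compounds named here, compound 2 holds the only number in the set; the other value shown is a limit, (the limit of > 12000 nM in this assay, at which 1 of the 2 values shown sits). Going by the values given here, the single measured step, an at least 2.0-fold lower number from compound 1 to compound 2 (0.30 log units; that floor lies within the scatter), is accordingly known only as a floor, and that floor lies within the usual scatter, so it does not settle whether the two compounds differ at all.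

Compound 3, `CC(/C=N/Nc1ccc([N+](=O)[O-])cc1)=N\NC(=O)c1ccccc1N`, differs from compound 2 by one change: amino in place of methyl on an aromatic carbon. Among the compounds with values here, no measured step covers an amino group at that carbon; the one step in hand, from chloro to methyl, gives no direction for it and is itself capped by a limit. With nothing in the data pointing either way, the working expectation is a step of about no change at the digits printed from compound 2 to compound 3 (within the scatter), that is, no change beyond the scatter. Compound 3 is therefore estimated at 6000 nM in this assay, with a range of 2000 nM to 20000 nM, and a fair chance that only a limit is reported.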

Compound 3, half-maximal inhibitory concentration: 4900 nM
The estimate for compound 3 lay 1.2-fold (0.09 log units) above the measured number; low and high end bracket the measured number.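

Amino in place of methyl on this aromatic carbon, ortho to a large group, gives a 1.2-fold lower number from compound 2 to compound 3 (0.09 log units; within the scatter) in this assay, so the two groups are not told apart here, even though amino brings a hydrogen-bond donor and a hydrogen-bond acceptor that methyl lacks. Amino in place of chloro gives an at least 2.4-fold lower number from compound 1 to compound 3 (0.38 log units; beyond the scatter), the first step in the series at this position whose floor clears the scatter, whereas the floor of the step from chloro to methyl did not. Compound 1 reaches only a limit, so this step is known as a floor and not as a size: the limit of > 12000 nM in this assay, at which 1 of the 3 values shown sits.

The compounds shown leave open how a hydroxyl, a methoxy or an acetylamino group on this carbon would read, and whether an amino group would read the same on another carbon of the ring. They also leave open how large the step from chloro to amino really is, and whether a group exists at this position that moves the number well away from the values of compound 2 and compound 3.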